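The compounds below may be only part of what the source reports. "The series", "measured", "known", "first", "only" and "open" are said of these compounds alone.

Compound 1: `COc1ccc2c(c1)c(-c1cc(C(F)(F)F)ccn1)cn2S(=O)(=O)c1ccc(C)cc1` — in a functional assay on A549 cells (Homo sapiens) for inhibition, tested at 100 uM (on this read-out lower numbers stand for a weaker effect and higher numbers for a stronger effect at the one concentration tested), compound 1 gives 35.9%.
Compound 2: `Cc1ccc(S(=O)(=O)n2cc(-c3cc(C(F)(F)F)ccn3)c3ccccc32)cc1` — in this assay compound 2 gives 30.5%.
Compound 3: `COc1ccc2c(c1)c(-c1cc(C(F)(F)F)cc(-c3cn(S(=O)(=O)c4ccc(C)cc4)c4ccc(OC)cc34)n1)cn2S(=O)(=O)c1ccc(C)cc1` — in this assay compound 3 gives 41.7%.

Among these three numbers compound 2 sits at the low end. Going by the values given here, its nearest neighbour is compound 1, and the one measured step between them, a number 5.4 percentage points lower from compound 1 to compound 2 (within the scatter), lies within the scatter, so the two cannot be told apart on this read-out. Among the compounds with values here, compound 3 stands further off; its value is beyond the scatter above that of compound 2, though no single-point step between them is given.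

The unmeasured compound 4, `Cc1ccc(S(=O)(=O)n2cc(-c3cc(C(F)(F)F)ccn3)c3cc(OCc4ccccc4)ccc32)cc1`, differs from compound 2 in one place: benzyloxy in place of hydrogen on an aromatic carbon. Within the data shown here, the only measured step that bears on a change at this kind of position is the one from compound 1 to compound 2, where removing a methoxy group lowered the number by an amount within the scatter. Putting a benzyloxy group at the same kind of place is a larger change than that, and nothing measured here tells how much larger a group at this position shifts the read-out. The expectation for compound 4 in this assay is therefore a step of a number 5.5 percentage points higher from compound 2 to compound 4 (within the scatter), that is, no move beyond the scatter. Compound 4 is estimated at 36%, with a range from 20% to 55%.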

Compound 4, a percentage reported as inhibition, at one concentration (the size of the read-out at that concentration, not a potency): 35.9%
Estimate against measurement, compound 4: 0.1 percentage points above; the measured number falls inside the stated range.
By their numbers in this assay, from the lowest: compounds 2, 1, 4 and 3 (each within the scatter of the next, the first and the last beyond it).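

In this assay, this aromatic carbon accepts benzyloxy in place of hydrogen, a substituent that brings a whole six-membered aromatic ring of carbon only, without the read-out leaving the scatter (a number 5.4 percentage points higher from compound 2 to compound 4 (within the scatter)). The earlier compounds had shown only the exchange of methoxy and hydrogen here, whereas compound 4 also allows the methoxy group to be compared with its phenyl-bearing counterpart, phenyl in place of hydrogen on the saturated chain carbon bound to the oxygen (no change at the digits printed from compound 1 to compound 4 (within the scatter)). Compound 1, compound 2 and compound 4 therefore cannot be told apart on this read-out, whichever of hydrogen, methoxy or benzyloxy occupies the position, and nothing available gives a reason for this.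

The compounds shown leave open whether an amine or a carboxylic acid on this same aromatic carbon would carry the number beyond the scatter. They also leave open whether compound 1, compound 2 and compound 4, alike at the one concentration tested, would remain alike across a range of concentrations.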